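Thiourea sulfonamide series: thiazolyl replacement on sulfonamide nitrogen

The source may report more compounds than this note shows. Statements on the series, on what has been measured and on what is new or still open speak of the compounds shown alone.

Working notes on a functional assay on HeLa cells (Homo sapiens) for antiproliferative activity, read by sulforhodamine B assay, with a stated time of 48 h; a lower number here means a stronger inhibitor, a higher number a weaker inhibitor. Compound 1 `O=C(Nc1ccccc1)Nc1ccc(S(=O)(=O)Nc2ccnc3cc(C(F)(F)F)ccc23)cc1` gives 41000 nM. Compound 2 `CC(=O)NS(=O)(=O)c1ccc(N/C(S)=N\c2ccnc3cc(C(F)(F)F)ccc23)cc1` gives 37600 nM. Compound 3 `N=C(N)NS(=O)(=O)c1ccc(N/C(S)=N\c2ccnc3cc(C(F)(F)F)ccc23)cc1` gives 23900 nM, the lowest of the three numbers, though it sits within the scatter of both compound 2 and compound 1. Going by the values given here, the only step measured on this nitrogen is a 1.6-fold lower number from compound 2 to compound 3 (0.20 log units; within the scatter), a change in the group carried by the sulfonamide nitrogen that left the number essentially where it was.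

Compound 4 `O=S(=O)(Nc1nccs1)c1ccc(N/C(S)=N\c2ccnc3cc(C(F)(F)F)ccc23)cc1` differs from compound 3 by a group of 5 heavy atoms (3 carbon, 1 nitrogen, 1 sulfur; one five-membered aromatic ring with 2 hetero atoms) in place of a group of 3 heavy atoms (1 carbon, 2 nitrogen; no ring), on a sulfonamide nitrogen. Among the compounds with values here, no measured pair puts an aromatic ring on that nitrogen, so the bearing of the one relevant step is indirect: it shows that exchanging the group on this sulfonamide nitrogen, within the changes tried, did not move this assay beyond the scatter. The expectation for compound 4 is therefore a step of a 1.0-fold higher number from compound 3 to compound 4 (0.02 log units; within the scatter), no change beyond the scatter, in either direction. Compound 4 is estimated at 25000 nM, with a range from 8000 nM to 75000 nM.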

Compound 4, half-maximal inhibitory concentration: 95200 nM
The estimate for compound 4 lay 3.8-fold (0.58 log units) below the measured number, and the stated range ends below it.
By their numbers in this assay, from the lowest: compounds 3, 2 and 1 (each within the scatter of the next); then compound 4.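

In this assay, the group on the sulfonamide nitrogen now makes a difference: 1,3-thiazol-2-yl in place of the group of compound 3 gives a 4.0-fold higher number from compound 3 to compound 4 (0.60 log units; beyond the scatter) and, in place of acetyl, gives a 2.5-fold higher number from compound 2 to compound 4 (0.40 log units; beyond the scatter), both beyond the scatter, whereas the earlier step on this nitrogen stayed within it. Among the three groups compared on this nitrogen, only the one carrying a ring stands apart, with the highest number, though a single ring-bearing example supports no general rule. Nothing available bears on why the number rose.

The compounds shown do not tell whether this rise belongs to aromatic rings on this nitrogen generally or to 1,3-thiazol-2-yl alone, which a phenyl or pyridin-2-yl group could separate. As far as these compounds go, how a methyl group or a plain hydrogen on the same nitrogen would read also remains open.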